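The source may hold more compounds than are shown below. What is called first, only, known or untested is meant among the compounds shown, and "the series" means these compounds.

Measured so far:
- compound 1 `COc1ccc(-c2cc(=O)c3c(OC)cc(OC)cc3n2C)cc1`: "not determined" (no result reported) in a functional assay on HepG2 cells (Homo sapiens) for antiproliferative activity, with a stated time of 72 h; a lower number here means that less compound is needed, a higher number that more compound is needed for the effect
- compound 2 `COc1ccc(-c2cc(=O)c3c(OC)cc(OC)cc3n2Cc2ccccc2)cc1`: > 17300 nM in this assay

Compound 2 has only a limit in this assay and no single number; its value is the limit given by the limit of > 17300 nM in this assay, at which 1 of the 2 values shown sits. The new compound 3 `C=CCNC(=O)n1c(-c2ccc(OC)cc2)cc(=O)c2c(OC)cc(OC)cc21` differs from compound 2 in one place: allylcarbamoyl in place of benzyl on an aromatic nitrogen. Among the compounds with values here, no measured step between two compounds exists here, so nothing shows how a change on that nitrogen moves the result. With compound 2 giving > 17300 nM, the expected step that the limit leaves unreadable from compound 2 to compound 3 is small, with no clear direction beyond the usual scatter. Compound 3 is therefore estimated at 20000 nM, within a range from 5000 nM to 60000 nM.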

Compound 3, half-maximal effective concentration: > 20000 nM
Compound 3: a limit, no number; the forecaster's own chance of this, stated with the estimate: 65%; the middle value sits exactly at the limit.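

Within the data shown here, compound 2 and compound 3 both give only limits in this assay, not numbers, and no step between them can be read. As far as these compounds go, whether any group on that aromatic nitrogen gives a measurable value stays open.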